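Exchanging a Flexible Chain for a Sulfonyl Pyrrolidine Ring

A few compounds are considered here, and "the series" means these few. Any claim that something is new, unique, unknown or untested is made for them only; others in the source may bear on it.

Of the compounds shown here, three have been tested in an assay on isolated protein for inhibition of eIF-2-alpha kinase GCN2 (Homo sapiens); on this read-out lower numbers stand for stronger inhibition and higher numbers for weaker inhibition. Compound 1 `CCn1cc(Nc2ccn3ncc(-c4ccc(OC)cc4)c3n2)cn1` gives > 1000 nM, which is a limit of the assay rather than a number. Compound 2 `COCCNC(=O)CNc1ncc2c(Br)nn(-c3ccc4ncccc4c3)c2n1` likewise gives only a limit, > 1000 nM, and so it stands at the limit of > 1000 nM in this assay, at which 2 of the 3 values shown sit. Compound 3 `COCCNC(=O)[C@H]1CC[C@@H](Nc2ncc3c(Br)nn(-c4ccc5ncccc5c4)c3n2)C1` gives 61 nM in this assay. Compound 4 `CS(=O)(=O)N1CC[C@@H](Nc2ncc3c(Br)nn(-c4ccc5ncccc5c4)c3n2)C1` awaits measurement; it differs from compound 2 by 1-(methylsulfonyl)pyrrolidin-3-yl in place of ((2-methoxyethyl)carbamoyl)methyl on a nitrogen on an aromatic ring. For the measured compounds named here, no measured pair changes in only one place, so the size of such a step has not yet been seen. A large gain in this assay is nonetheless expected, an at least 8.3-fold lower number from compound 2 to compound 4 (0.92 log units; beyond the scatter). This expectation rests on compound 3, which gives 61 nM. Compound 4 is estimated at 120 nM, most likely between 30 nM and 500 nM.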

Compound 4, half-maximal inhibitory concentration: 90 nM
The estimate for compound 4 lay 1.3-fold (0.12 log units) above the measured number, within the range that was stated.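

In this assay, exchanging the open chain ((2-methoxyethyl)carbamoyl)methyl for the ring-bearing 1-(methylsulfonyl)pyrrolidin-3-yl on this nitrogen gives an at least 11-fold lower number from compound 2 to compound 4 (1.04 log units; beyond the scatter). For the compounds shown here, this is the first step seen at this position, and it is large. Compound 2 gives > 1000 nM, which is a limit of the assay, so the step is only a minimum: the limit of > 1000 nM in this assay, at which 2 of the 4 values shown sit.

The change brings in the ring and the sulfonyl group together, and the compounds shown do not tell which of them matters. A pyrrolidine carrying an acetyl group instead of methylsulfonyl would begin to separate the two.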